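Ester chain extension on the dichloropyridyl vinyl isoxazole core

A few compounds are considered here, and "the series" means these few. Any claim that something is new, unique, unknown or untested is made for them only; others in the source may bear on it.

Working notes on the series. Compound 1 `CCOC(=O)c1cc(/C=C/c2c(Cl)cncc2Cl)on1` carries an ethyl ester on the shared core. In an ADME assay on Vero cells (Chlorocebus sabaeus) for cytotoxicity, with a stated time of 72 h (on this read-out lower numbers stand for stronger inhibition and higher numbers for weaker inhibition), compound 1 is reported only at the limit of the assay, > 128000 nM; this is a limit, not a measured number. Compound 2 `CCOC(=O)c1cc(/C=C/c2cccc(OC)n2)on1` has no result in this assay, "not determined" (no result reported). The one numerical anchor is therefore (the limit of > 128000 nM in this assay, at which 1 of the 2 values shown sits), so compound 1 stands at the limit and nowhere more exact. Among the compounds with values here, no step between measured compounds exists in this set.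

Compound 3 `CCCCCCC(C)OC(=O)c1cc(/C=C/c2c(Cl)cncc2Cl)on1` is the untested member. Its difference from compound 1 is hexyl in place of hydrogen on a saturated chain carbon bound to an oxygen next to a carbonyl group and a saturated chain carbon. Within the data shown here, with no measured step to build on, the expectation for compound 3 is a value near the limit, with a possible shift toward somewhat stronger inhibition that may or may not exceed the scatter. Compound 3 is estimated at 90000 nM, within 25000 nM to 200000 nM, which means an expected step of an at least 1.4-fold lower number from compound 1 to compound 3 (0.15 log units; that floor lies within the scatter).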

Compound 3, half-maximal inhibitory concentration: > 128000 nM
Compound 3 gave a limit, no number (the forecaster's own chance of this, stated with the estimate: 55%); middle value at least 1.4-fold (0.15 log units) from the limit.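

Within the data shown here, compound 1 and compound 3 both stand only as limits in this assay, and no step between them can be read. The compounds shown leave open whether the change from ethyl to 1-methylheptyl alters the read-out at all, and in which direction.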